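A few compounds are considered here, and "the series" means these few. Any claim that something is new, unique, unknown or untested is made for them only; others in the source may bear on it.

Measured compounds:
- compound 1, `CCCCCC(=O)O[C@H]1[C@H](O)[C@H](n2ccc(N)nc2=O)O[C@@H]1CO`: 0.05 ug/mL
- compound 2, `CCCCCCCCCCCCCC(=O)O[C@H]1[C@H](O)[C@H](n2ccc(N)nc2=O)O[C@@H]1CO`: 0.08 ug/mL
- compound 3, `CCCC(=O)O[C@H]1[C@H](O)[C@H](n2ccc(N)nc2=O)O[C@@H]1CO`: 0.11 ug/mL

In a functional assay on HeLa cells (Homo sapiens) for cytotoxicity, read by cell counting, with a stated time of 48 h (on this read-out lower numbers stand for an effect already at smaller amounts and higher numbers for an effect only at larger amounts of compound), compound 1 gives the lowest of the three numbers. Its nearest neighbour is compound 2, with a 1.6-fold higher number from compound 1 to compound 2 (0.20 log units; within the scatter); the furthest is compound 3, with a 2.2-fold higher number from compound 1 to compound 3 (0.34 log units; beyond the scatter). Between the other two the data show a 1.4-fold higher number from compound 2 to compound 3 (0.14 log units; within the scatter).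

Compound 4, `CCCCCC(=O)OC[C@H]1O[C@@H](n2ccc(N)nc2=O)[C@@H](O)[C@@H]1OC(=O)CCCCC`, differs from compound 1 by pentylcarbonyl in place of hydrogen on an oxygen on a saturated carbon. For the measured compounds named here, all three measured steps change only the length of the one ester chain; none adds a second acyl group at another oxygen of the shared core, so no measured step bears directly on this change. The three chain variations themselves stayed small, two of them within the scatter, which suggests that the acyl part of these molecules can be altered without a large shift in this assay. The account therefore expects for compound 4 a step of a 1.6-fold higher number from compound 1 to compound 4 (0.20 log units; within the scatter), with no clear direction beyond the scatter, and estimates 0.08 ug/mL with a range from 0.025 ug/mL to 0.3 ug/mL.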

Compound 4, concentration for half-maximal effect: 0.07 ug/mL
Estimate against measurement, compound 4: 1.1-fold (0.06 log units) above; low and high end bracket the measured number.
By their numbers in this assay, from the lowest: compounds 1, 4, 2 and 3 (each within the scatter of the next, the first and the last beyond it).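

In this assay, adding pentylcarbonyl on the oxygen on a saturated carbon, which turns hydroxymethyl into ((pentylcarbonyl)oxy)methyl, gives a 1.4-fold higher number from compound 1 to compound 4 (0.15 log units; within the scatter). The earlier compounds shown here varied only the length of the one ester chain, whereas this step shows that a second ester group at another oxygen of the shared core also leaves the number within the scatter of compound 1. No measurement shown here accounts for this result.

From the compounds shown here alone, whether a longer chain at this oxygen would stay as close to compound 1 remains open, as does the outcome for an amine or a carboxylic acid carried on the acyl group. The compounds shown also leave open what would follow from replacing the ester link at this oxygen with an amide.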